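A Fluorophenyl Swap Where Every Neighbour Sits at a Limit

A few compounds are considered here, and "the series" means these few. Any claim that something is new, unique, unknown or untested is made for them only; others in the source may bear on it.

Measured so far:
compound 1, `Cc1cccc(S(=O)(=O)Nc2ccc(-c3nc4ccccc4o3)cc2)c1`: in an assay on isolated protein for inhibition of malate dehydrogenase, mitochondrial (Sus scrofa), with stated times of 45 min and 30 min (on this read-out higher numbers stand for weaker inhibition and lower numbers for stronger inhibition), compound 1 gives > 63000 nM, which is a limit of the assay and not a number.
compound 2, `O=S(=O)(Nc1ccc2oc(-c3ccccc3)nc2c1)c1ccccc1Cl`: compound 2 gives > 63000 nM, again a limit.
compound 3, `O=S(=O)(Nc1ccc(-c2nc3ccccc3o2)cc1)c1cccc(C(F)(F)F)c1`: compound 3 gives > 63000 nM, again a limit.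

Compound 1 therefore stands only at a limit in this assay, and nothing places it above or below its two neighbours. Going by the values given here, the one step that can be drawn, a step that the two limits leave unreadable from compound 1 to compound 3, cannot be read because both ends sit at the limit of > 63000 nM in this assay, at which 3 of the 3 values shown sit.

The compound not yet measured is compound 4, `O=S(=O)(Nc1ccc(-c2nc3ccccc3o2)cc1)c1ccc(F)cc1`. It differs from compound 1 in one place: 4-fluorophenyl in place of 3-methylphenyl on a sulfonyl sulfur.

Among the compounds with values here, no measured step bears readably on this change, so there is no ground to expect a shift in either direction, and the most that can be said is that the shared core has not yet given a readable value in this assay. The step from compound 1 to compound 4 is expected to be a step that the limit leaves unreadable from compound 1 to compound 4. Compound 4 is accordingly expected to give about 100000 nM, within a range of 20000 nM to 500000 nM, most likely reported as a limit once more.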

Compound 4, half-maximal inhibitory concentration: > 63000 nM
Compound 4: a limit, no number (the forecaster's own chance of this, stated with the estimate: 85%); the middle value does not contradict the limit.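

The step from compound 1 to compound 4 cannot be read, because both compounds stand at a limit and not at a number: the limit of > 63000 nM in this assay, at which 4 of the 4 values shown sit.

The compounds shown leave open whether any change to the shared core would give a readable number in this assay.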